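A few compounds are considered here, and "the series" means these few. Any claim that something is new, unique, unknown or untested is made for them only; others in the source may bear on it.

Measured in a functional assay on NCI-H460 cells (Homo sapiens) for cytotoxicity, read by MTT assay, with a stated time of 72 h; a higher number here means a weaker inhibitor, a lower number a stronger inhibitor:
- compound 1, `CCN(CC)Cc1ccc2nc(NC(=O)N/N=C/c3cn(Cc4ccccc4Cl)c4ccccc34)sc2c1`, gives 980 nM
- compound 2, `CCN(CC)Cc1ccc2nc(NC(=O)N/N=C3\C(=O)Nc4ccc(F)cc43)sc2c1`, gives 1060 nM

Compound 1 has the lower of the two numbers in this assay, but the gap to compound 2 lies within the scatter of repeated measurements, so the two cannot be told apart on these data. Among the compounds with values here, no step between measured compounds that differ in one place is available, and compound 2 departs from compound 1 in a different part of the molecule than the change under study.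

Compound 3, `CCN(CC)Cc1ccc2nc(NC(=O)N/N=C/c3c[nH]c4ccccc34)sc2c1`, is not yet measured. It differs from compound 1 as follows: hydrogen in place of 2-chlorobenzyl on an aromatic nitrogen. Within the data shown here, no measured pair here shows what such a change does, so the expectation rests on compound 1 alone. A modest weakening, somewhat beyond the scatter, is expected, giving an estimated step of a 2.6-fold higher number from compound 1 to compound 3 (0.41 log units; beyond the scatter). Compound 3 is estimated at 2500 nM, with a range from 800 nM to 8000 nM; the lower end of that range allows for no change beyond the scatter.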

Compound 3, half-maximal inhibitory concentration: 3140 nM
For compound 3 the middle estimate is 1.3-fold (0.10 log units) below the measured one; the range from low to high includes it.
By their numbers in this assay, from the lowest: compounds 1 and 2 (each within the scatter of the next); then compound 3.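

Within the data shown here, on the aromatic nitrogen of the five-membered ring, this is the first change that can be read in one place: in this assay, hydrogen in place of 2-chlorobenzyl gives a 3.2-fold higher number from compound 1 to compound 3 (0.51 log units; beyond the scatter) and so a modest loss beyond the scatter. The position therefore responds to this substitution, yet the 2-chlorobenzyl group is not required for a measurable value, as compound 3 still gives 3140 nM in this read-out. Nothing available here explains the step.

On these data alone, whether a methyl, a plain benzyl or a longer chain on the same nitrogen would match compound 1 remains open, as does the share of the step that belongs to the chlorine. Also open, as far as these compounds go, is whether the step keeps its size when another part of the molecule changes.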